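Pyrazole for benzimidazole on the diarylamine series

A few compounds are considered here, and "the series" means these few. Any claim that something is new, unique, unknown or untested is made for them only; others in the source may bear on it.

The set comprises two measured diarylamines and one unmeasured analogue. Compound 1 `CCN(c1ccc(C#N)c(Cl)c1)c1cc(-n2cnc3ccccc32)ccc1C` carries a 1H-benzimidazol-1-yl on the tolyl ring of the shared core. In a functional assay on PC-3 cells (Homo sapiens) for antiproliferative activity, read by CCK-8 assay, with a stated time of 6 days (on this read-out higher numbers stand for weaker inhibition and lower numbers for stronger inhibition), compound 1 gives 8160 nM. Compound 2 `N#Cc1ccc(N2CCCc3c(-c4ccncc4)cccc32)cc1C(F)(F)F`, a ring-fused analogue with a pyridinyl group, is the only other measured entry; in this assay compound 2 gives 28700 nM. On these two numbers compound 1 stands lowest, and the gap to compound 2 lies beyond the scatter.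

Compound 3 `CCN(c1ccc(C#N)c(Cl)c1)c1cc(-c2cn[nH]c2)ccc1C` has not been measured. It differs from compound 1 in one place: 1H-pyrazol-4-yl in place of 1H-benzimidazol-1-yl on an aromatic carbon. Among the compounds with values here, no step between measured compounds covers this exchange, so the expectation rests only on compound 1. The expected step from compound 1 to compound 3 is a 1.5-fold higher number from compound 1 to compound 3 (0.17 log units; within the scatter), that is a small loss, not clearly beyond the scatter, since the smaller ring system leaves the rest of the core intact. Compound 3 is therefore estimated at 12000 nM in this assay, with a range from 3500 nM to 40000 nM.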

Compound 3, half-maximal inhibitory concentration: 15300 nM
Compound 3: middle estimate off by 1.3-fold (0.11 log units), on the low side; the range from low to high includes it.
By their numbers in this assay, from the lowest: compounds 1, 3 and 2 (each within the scatter of the next, the first and the last beyond it).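

In this assay, within the data shown here, the exchange of 1H-benzimidazol-1-yl for 1H-pyrazol-4-yl on this aromatic carbon gives a 1.9-fold higher number from compound 1 to compound 3 (0.27 log units; within the scatter) and is the first reading of any change at this place on the shared core. The position, meta to a large group and para to a methyl group, thus accepts a group of 5 heavy atoms with one five-membered aromatic ring and 1 hydrogen-bond donor in place of a group of 9 heavy atoms with two aromatic rings and 0 hydrogen-bond donors, and the read-out does not separate compound 1 from compound 3. No measured property of either group is at hand to account for this outcome.

Going by these compounds, whether a morpholine, a carboxylic acid or a plain methoxy group on the same carbon would also stay within the scatter of compound 1 remains open, since both groups seen here are aromatic rings with 2 ring nitrogens. Also open, on these data alone, is how this exchange would read with a longer chain, such as propyl, in place of the ethyl group on the amine nitrogen of the core.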